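Swapping the acrylamide vinyl for a longer chain

The source may hold more compounds than are shown below. What is called first, only, known or untested is meant among the compounds shown, and "the series" means these compounds.

Measured in a functional assay on A549 cells (Homo sapiens) for antiproliferative activity, read by MTT assay, with a stated time of 72 h; on this read-out higher numbers stand for weaker inhibition and lower numbers for stronger inhibition:
Compound 1 `C=CC(=O)Nc1cccc(Oc2nc(Nc3ccn(C)n3)nc3c2CSCC3)c1`: 18600 nM
Compound 2 `CCC/C=C/C(=O)Nc1cccc(Oc2nc(Nc3cccc(OC)c3)nc3c2CSCC3)c1`: 11800 nM
Compound 3 `C=CC(=O)Nc1cccc(Oc2nc(Nc3cccc(C#N)c3)nc3c2CSCC3)c1`: 6860 nM

Compound 3 stands clearly apart from compound 1, but its gap to compound 2 lies within the scatter, so those two cannot be told apart. The next structure, compound 4 `CCC/C=C/C(=O)Nc1cccc(Oc2nc(Nc3cccc(C#N)c3)nc3c2CSCC3)c1`, has pent-1-en-1-yl in place of vinyl on a carbonyl carbon.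

Among the measured compounds shown here, no measured step makes this exact change. The only one available is a 2.7-fold lower number from compound 1 to compound 3 (0.43 log units; beyond the scatter), which alters the group on a nitrogen on an aromatic ring, so it says little about the chain. The nearest clue is compound 2, which already carries pent-1-en-1-yl and gives 11800 nM. It differs from compound 3 in another place too, so this clue is indirect, but it gives no sign of a large change. In this assay, no step beyond the scatter is therefore expected.

The expected result is a 1.2-fold higher number from compound 3 to compound 4 (0.07 log units; within the scatter). The estimated value for compound 4 is 8000 nM, within an expected range of 3500 nM to 18000 nM.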

Compound 4, half-maximal inhibitory concentration: 5790 nM
Compound 4: middle estimate off by 1.4-fold (0.14 log units), on the high side; the measured number falls inside the stated range.
By their numbers in this assay, from the lowest: compounds 4, 3, 2 and 1 (each within the scatter of the next, the first and the last beyond it).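

In this assay, among the compounds shown here, the change from vinyl to pent-1-en-1-yl on the carbonyl carbon gives a 1.2-fold lower number from compound 3 to compound 4 (0.07 log units; within the scatter) and so is the first direct look at this chain, with only the chain differing between the two compounds. The longer chain, with its added carbons, leaves the number within the usual scatter in the presence of the cyano group. With pent-1-en-1-yl held fixed, cyano in place of methoxy on an aromatic carbon gives a 2.0-fold lower number from compound 2 to compound 4 (0.31 log units; beyond the scatter) as a modest step, while nothing available explains either result.

From the compounds shown here alone, it remains open whether a chain carrying a dimethylamino group would leave the number similarly unchanged at this carbonyl carbon. The same question stands for a saturated pentyl chain, which lacks the double bond.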